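Moving a Hydroxyl on a Pyridine-Linked Aryl Pair

This account rests on a few compounds, and the source may have more. Where it says the series, first, only, none or still open, it means among the compounds named here.

The study looks at compound 2, `Oc1cccc(-c2cc(-c3cccc(C(F)(F)F)c3)cc(-c3ccccc3O)n2)c1`, and its rearranged relative compound 3, `Oc1cccc(-c2cc(-c3cccc(C(F)(F)F)c3)cc(-c3cccc(O)c3)n2)c1`, alongside compound 1, `Oc1cccc(-c2cc(-c3ccc(F)cc3)cc(-c3cccc(O)c3)n2)c1`. In a functional assay on DU-145 cells (Homo sapiens) for inhibition (on this read-out higher numbers stand for weaker inhibition and lower numbers for stronger inhibition), compound 1 gives 7120 nM. Among the compounds with values here, in the same assay compound 2 gives 13000 nM, the higher of the two numbers so far, although its gap to compound 1 lies within the scatter, so no order between them can be drawn. Compound 3 differs from compound 2 in one place: 3-hydroxyphenyl in place of 2-hydroxyphenyl on an aromatic carbon. The atoms stay the same; only the point of attachment of the hydroxyl on that ring moves. Within the data shown here, no directly measured pair covers this move, so its size is open. Compound 1 already carries the 3-hydroxyphenyl group at both positions flanking the ring nitrogen and sits at 7120 nM, which suggests that this arrangement is tolerated. The step of a 1.6-fold lower number from compound 2 to compound 3 (0.21 log units; within the scatter) is therefore expected to be small, within or near the scatter, and toward a lower number. Compound 3 is estimated at 8000 nM, with a range from 3000 nM to 25000 nM.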

Compound 3, half-maximal inhibitory concentration: > 50000 nM
Compound 3: a limit, no number; the forecaster's own chance of this, stated with the estimate: 10%; at least 6.2-fold (0.79 log units) between middle value and limit.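

In this assay, the hydroxyl's place on the aryl ring next to the ring nitrogen matters even though the atoms stay the same: moving from 2-hydroxyphenyl to 3-hydroxyphenyl gives an at least 3.8-fold higher number from compound 2 to compound 3 (0.58 log units; beyond the scatter). Compound 3 stands as a limit and not a number: the limit of > 50000 nM in this assay, at which 1 of the 3 values shown sits. The group at the other position matters as well, since 3-(trifluoromethyl)phenyl in place of 4-fluorophenyl, with both 3-hydroxyphenyl groups kept, gives an at least 7.0-fold higher number from compound 1 to compound 3 (0.84 log units; beyond the scatter), so two 3-hydroxyphenyl groups do not by themselves set the read-out.

Both steps end at a limit, so their full size stays open, and the compounds shown give no reason for the weaker inhibition. Also open, on these data alone, is how the position next to the ring nitrogen would read with a 4-hydroxyphenyl group, a methoxyphenyl group or an aminophenyl group, and whether 2-hydroxyphenyl would keep its advantage over 3-hydroxyphenyl alongside 4-fluorophenyl rather than 3-(trifluoromethyl)phenyl.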